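This account rests on a few compounds, and the source may have more. Where it says the series, first, only, none or still open, it means among the compounds named here.

Measured in a functional assay for activation of Alpha-1D adrenergic receptor (Homo sapiens), read by calcium flux; on this read-out higher numbers stand for an effect only at larger amounts of compound and lower numbers for an effect already at smaller amounts:
Compound 1 `c1ccc(-c2cnccn2)c(OCC2=NCCN2)c1` gives < 100000 nM, a limit of this assay and not a number.
Compound 2 `c1ccc(-c2ccncn2)c(OCC2=NCCN2)c1` gives < 100000 nM, likewise a limit.
Compound 3 `c1c[nH]c(-c2ccccc2OCC2=NCCN2)c1` gives 6.31 nM.

Among the compounds with values here, compound 3 thus stands as the only value with a number among the three; the other two values sit at the limit of < 100000 nM in this assay, at which 2 of the 3 values shown sit. The steps a step that the two limits leave unreadable from compound 1 to compound 2, a step that the limit leaves unreadable from compound 1 to compound 3 and a step that the limit leaves unreadable from compound 2 to compound 3 cannot be sized for that reason.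

Compound 4 `c1ccc(-c2ccsc2)c(OCC2=NCCN2)c1` is not yet measured. It differs from compound 3 by thiophen-3-yl in place of 1H-pyrrol-2-yl on an aromatic carbon. Within the data shown here, none of the measured steps covers an exchange of this kind, and the three steps that are recorded are all unreadable because of the limit of < 100000 nM in this assay, at which 2 of the 3 values shown sit. Among the measured compounds shown here, the expectation therefore rests on compound 3 alone, whose value in this assay is 6.31 nM, with a wide allowance for an exchange that has no measured counterpart.

Compound 4 is expected to give about 30 nM, estimated within 5 nM to 300 nM. The step of a 4.8-fold higher number from compound 3 to compound 4 (0.68 log units; beyond the scatter) is expected to be modest and toward weaker activity, but a result within the scatter of compound 3 is also plausible.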

Compound 4, half-maximal effective concentration: 12.6 nM
Compound 4: the middle estimate sits 2.4-fold (0.38 log units) above what was measured; the measured number falls inside the stated range.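

In this assay the exchange of 1H-pyrrol-2-yl for thiophen-3-yl gives a 2.0-fold higher number from compound 3 to compound 4 (0.30 log units; within the scatter) and so adds a second numbered value at this place on the shared core. Between these two groups, the hydrogen-bond donor counted on 1H-pyrrol-2-yl is not required for such a value, since thiophen-3-yl carries none. The steps to compound 4 from the pyrazin-2-yl compound 1 and the pyrimidin-4-yl compound 2 cannot be read, and these two groups cannot be ranked against thiophen-3-yl: the limit of < 100000 nM in this assay, at which 2 of the 4 values shown sit.

On these data alone, whether the attachment point of the five-membered ring matters remains open, as thiophen-2-yl and 1H-pyrrol-3-yl do not appear here. Also open, as far as these compounds go, is how an unsubstituted phenyl ring or a basic amine such as piperidin-1-yl would read at this place.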